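The source may hold more compounds than are shown below. What is called first, only, known or untested is meant among the compounds shown, and "the series" means these compounds.

Working notes on the series. In a functional assay on MDA-MB-435 cells (Homo sapiens) for inhibition (on this read-out higher numbers stand for weaker inhibition and lower numbers for stronger inhibition), compound 1 `COc1cc[nH]c1/C=C1\C(=O)Nc2ccc(F)c(C#C[C@@H](C)O)c21` gives 110 nM, compound 2 `CCN[C@H](C#Cc1c(F)ccc2c1/C(=C/c1[nH]ccc1OC)C(=O)N2)CO` gives 1160 nM and compound 3 `COc1cc[nH]c1/C=C1\C(=O)Nc2ccc(F)c(C#CC3(O)CCOCC3)c21` gives 600 nM. Compound 3 therefore stands with compound 2 and apart from compound 1, the only one of the three whose number is clearly the lowest.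

The next structure is compound 4 `COc1cc[nH]c1/C=C1\C(=O)Nc2ccc(F)c(C#C[C@@H]3C[C@H](O)CN3)c21`, which differs from compound 3 in one place, on a triple-bonded carbon: 4-hydroxypyrrolidin-2-yl in place of 4-hydroxyoxan-4-yl on a triple-bonded carbon.

Among the measured compounds shown here, no measured compound carries the 4-hydroxypyrrolidin-2-yl group, so the evidence is indirect. Replacing 1-hydroxyethyl with 4-hydroxyoxan-4-yl gave a 5.5-fold higher number from compound 1 to compound 3 (0.74 log units; beyond the scatter), and replacing it with 1-(ethylamino)-2-hydroxyethyl gave an 11-fold higher number from compound 1 to compound 2 (1.02 log units; beyond the scatter). The two replacement groups, one with nitrogen and one without, differ only by a 1.9-fold lower number from compound 2 to compound 3 (0.29 log units; within the scatter). Swapping one for the other has thus not moved the number beyond the scatter, and the same is expected here in this assay, with no clear direction. The expected step is a 1.2-fold lower number from compound 3 to compound 4 (0.08 log units; within the scatter). On these data alone, the range stays wide because the new ring is untested. For compound 4 the estimated value is 500 nM, with an expected range of 130 nM to 1800 nM.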

Compound 4, half-maximal inhibitory concentration: 110 nM
For compound 4 the middle estimate is 4.5-fold (0.66 log units) above the measured one, and the stated range ends above it.
By their numbers in this assay, from the lowest: compounds 1 and 4 (each within the scatter of the next); then compounds 3 and 2 (each within the scatter of the next).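

In this assay, putting 4-hydroxypyrrolidin-2-yl in place of 4-hydroxyoxan-4-yl on a triple-bonded carbon gives a 5.5-fold lower number from compound 3 to compound 4 (0.74 log units; beyond the scatter), and putting it in place of 1-(ethylamino)-2-hydroxyethyl gives an 11-fold lower number from compound 2 to compound 4 (1.02 log units; beyond the scatter), so this position does distinguish among groups that the earlier pair left within the scatter of each other. Against 1-hydroxyethyl the new group shows no change at the digits printed from compound 1 to compound 4 (within the scatter), which makes compound 4 the first replacement here that does not carry a higher number than compound 1. Neither a ring nor a nitrogen sorts the four compounds on its own: compound 4 has both and stands with compound 1, while compound 3 has a ring and compound 2 has a nitrogen, and both of those stand apart from that pair.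

Nothing measured on these compounds accounts for the gap between the two rings. Open too, on these data alone, is whether the ring nitrogen, the ring size or the two defined stereocentres carry the step, a question that 4-hydroxypiperidin-4-yl, pyrrolidin-2-yl without the hydroxyl, or the opposite stereoisomers of 4-hydroxypyrrolidin-2-yl at this position would help to separate.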